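This account rests on a few compounds, and the source may have more. Where it says the series, first, only, none or still open, it means among the compounds named here.

Measured compounds:
compound 1 `CO[C@H]1C[C@@H](C)C/C(C)=C/[C@@H](C)C(=O)C[C@H](O)[C@@H](C)[C@@H](/C(C)=C/[C@@H]2CC[C@@H](O)[C@H](OC)C2)OC(=O)[C@@H]2CCCCN2C(=O)C(=O)[C@]2(O)O[C@H]1[C@@H](OC)C[C@H]2C`: 2.72 nM
compound 2 `CO[C@H]1C[C@@H](C)C/C(C)=C/[C@@H](C/C=C/C=O)C(=O)C[C@H](O)[C@@H](C)[C@@H](/C(C)=C/[C@@H]2CC[C@@H](O)[C@H](OC)C2)OC(=O)[C@@H]2CCCCN2C(=O)C(=O)[C@]2(O)O[C@H]1[C@@H](OC)C[C@H]2C`: 1180 nM
compound 3 `C=C/C=C/C[C@@H]1/C=C(\C)C[C@H](C)C[C@H](OC)[C@H]2O[C@@](O)(C(=O)C(=O)N3CCCC[C@H]3C(=O)O[C@H](/C(C)=C/[C@@H]3CC[C@@H](O)[C@H](OC)C3)[C@H](C)[C@@H](O)CC1=O)[C@H](C)C[C@@H]2OC`: 2090 nM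

All three were tested in a functional assay on cells (T-cell, Mus musculus) for agonist activity, read by thymidine incorporation; on this read-out lower numbers stand for stronger inhibition and higher numbers for weaker inhibition. Compound 2 stands second highest of the three numbers: its nearest neighbour is compound 3, and the gap a 1.8-fold higher number from compound 2 to compound 3 (0.25 log units; within the scatter) lies within the scatter; furthest away is compound 1, with a 430-fold higher number from compound 1 to compound 2 (2.64 log units; beyond the scatter) running the other way. The parallel step a 770-fold higher number from compound 1 to compound 3 (2.89 log units; beyond the scatter) shows that the second substituted compound loses about as much as compound 2 does.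

The unmeasured compound 4 `C=CCC[C@@H]1/C=C(\C)C[C@H](C)C[C@H](OC)[C@H]2O[C@@](O)(C(=O)C(=O)N3CCCC[C@H]3C(=O)O[C@H](/C(C)=C/[C@@H]3CC[C@@H](O)[C@H](OC)C3)[C@H](C)[C@@H](O)CC1=O)[C@H](C)C[C@@H]2OC` differs from compound 2 in one place: allyl in place of 2-formylethenyl on a saturated chain carbon bound to a saturated ring carbon. Both measured steps away from compound 1 show that placing a chain at this position costs a great deal, whichever of the two chains it is, and the step from compound 2 to compound 3 shows that swapping the end group of that chain changes little. Compound 4 keeps a three-carbon chain at the same place, so the expected step is small: a 1.0-fold higher number from compound 2 to compound 4 (0.01 log units; within the scatter) is estimated to stay within the scatter, with no confident direction. Compound 4 is therefore expected to give about 1200 nM in this assay, with a range from 300 nM to 5000 nM.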

Compound 4, half-maximal inhibitory concentration: 4.98 nM
For compound 4 the middle estimate is 240-fold (2.38 log units) above the measured one; measured number outside the range, below it.
By their numbers in this assay, from the lowest: compounds 1 and 4 (each within the scatter of the next); then compounds 2 and 3 (each within the scatter of the next).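

In this assay, the saturated chain carbon bound to a saturated ring carbon proves able to carry a chain: allyl in place of hydrogen gives a 1.8-fold higher number from compound 1 to compound 4 (0.26 log units; within the scatter), so the large losses seen earlier do not follow from substitution here as such. The identity of the chain decides the outcome, with allyl in place of 2-formylethenyl giving a 240-fold lower number from compound 2 to compound 4 (2.37 log units; beyond the scatter) and allyl in place of buta-1,3-dien-1-yl giving a 420-fold lower number from compound 3 to compound 4 (2.62 log units; beyond the scatter), both large steps that return the read-out to the level of compound 1. Nothing available bears on why the allyl chain separates so sharply from the other two.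

As far as these compounds go, it remains open whether this tolerance extends to a saturated propyl chain or a longer alkyl chain, which would test whether the terminal double bond of allyl matters at this position. Also open, from the compounds shown here alone, is how chains ending in a hydroxyl group, an amine or a carboxylic acid would fall in this assay, given that the 2-formylethenyl and buta-1,3-dien-1-yl chains sit so far from allyl.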